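Aminomethyl in place of triazolyl: lipophilicity outlook for compound 4

This account rests on a few compounds, and the source may have more. Where it says the series, first, only, none or still open, it means among the compounds named here.

Compound 3 `CC[C@H](C)N1C(=O)C(C)(C)c2cnc(Nc3ccc(-c4nnc(C)[nH]4)cc3)nc21` gives 2.21 in a physicochemical assay for lipophilicity, read by HPLC, at pH 7 (a lower number here means a more polar compound, a higher number a more lipophilic compound), and stands lowest of the three measured compounds. Compound 1 `C[C@@H](c1ccc(F)cc1)N1C(=O)C(C)(C)c2cnc(Nc3cccnc3)nc21` gives 2.81, and compound 2 `CC[C@H](C)N1C(=O)C(C)(C)c2cnc(Nc3ccc(CN4CC(C)OC(C)C4)cc3)nc21` gives 3.98, the highest of the set. For the measured compounds named here, the one single-site step on record, a number 1.77 log units lower from compound 2 to compound 3 (beyond the scatter), is the exchange of the ring-bearing aminomethyl group of compound 2 for the triazolyl group of compound 3.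

Compound 4 `CC[C@H](C)N1C(=O)C(C)(C)c2cnc(Nc3ccc(CNC4CCCOC4)cc3)nc21` returns to a ring-bearing aminomethyl group at the same position: ((oxan-3-yl)amino)methyl in place of 5-methyl-4H-1,2,4-triazol-3-yl on an aromatic carbon. This change runs in the opposite sense to the step from compound 2 to compound 3, so a rise in this assay is expected, though the entering group is not the same as that of compound 2 and only part of that step is expected to be recovered. For compound 4 the estimate is 3, within 2.4 to 3.6, an expected step of a number 0.79 log units higher from compound 3 to compound 4 (beyond the scatter).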

Compound 4, distribution coefficient: 2.79
For compound 4 the middle estimate is 0.21 log units above the measured one; the measured number falls inside the stated range.
By their numbers in this assay, from the lowest: compound 3; then compounds 4 and 1 (each within the scatter of the next); then compound 2.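

Notes on the group on the aromatic carbon para to a large group: in this assay the ring-bearing aminomethyl groups do not share one level. With the aromatic attachment kept, (oxan-3-yl)amino in place of 2,6-dimethylmorpholin-4-yl on the saturated chain carbon gives a number 1.19 log units lower from compound 2 to compound 4 (beyond the scatter), so a change confined to the amine accounts for the larger part of a number 1.77 log units lower from compound 2 to compound 3 (beyond the scatter). The triazolyl and ((oxan-3-yl)amino)methyl groups carry equal hydrogen-bond donor and acceptor counts, yet the exchange still gives a number 0.58 log units higher from compound 3 to compound 4 (beyond the scatter), so those counts alone do not set the number across this pair.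

On these data alone, whether an acyclic amine such as dimethylaminomethyl or a carboxylic acid at this position would fall inside the span of compound 3 to compound 2 remains open. No available evidence explains any of these steps.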